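The source may report more compounds than this note shows. Statements on the series, on what has been measured and on what is new or still open speak of the compounds shown alone.

Four related amides share a nitrofuran carbonyl attached to an aminothiazole that carries an aryl group. Compound 1 `COc1ccc(-c2csc(NC(=O)c3ccc([N+](=O)[O-])o3)n2)cc1` and compound 2 `COc1ccccc1-c1csc(NC(=O)c2ccc([N+](=O)[O-])o2)n1` differ only in where the methoxy sits on that aryl ring. In an ADME assay on Vero cells (Chlorocebus sabaeus) for cytotoxicity, read by MTT assay, with a stated time of 72 h (a lower number here means a stronger inhibitor, a higher number a weaker inhibitor), compound 1 gives 63000 nM, and compound 2 gives 42000 nM; the change a 1.5-fold lower number from compound 1 to compound 2 (0.18 log units; within the scatter) is too small to count as a real difference. Compound 3 `Nc1cccc(-c2csc(NC(=O)c3ccc([N+](=O)[O-])o3)n2)c1` carries an aminophenyl instead, and in this assay its entry reads "not determined" (no result reported), so no number exists to place it against the other two.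

Compound 4 `O=C(Nc1nc(-c2cccc(NS(=O)(=O)Cc3ccccc3)c2)cs1)c1ccc([N+](=O)[O-])o1` is compound 3 with one change: benzylsulfonyl in place of hydrogen on a nitrogen on an aromatic ring. For the measured compounds named here, no measured step touches this nitrogen, and the only step available, between compound 1 and compound 2, concerns a methoxy position and lies within the scatter. The expectation therefore rests on the whole set being weakly cytotoxic. Compound 4 is expected to give roughly 50000 nM in this assay, with a plausible range from 15000 nM to 200000 nM.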

Compound 4, half-maximal inhibitory concentration: 59300 nM
Compound 4: the middle estimate sits 1.2-fold (0.07 log units) below what was measured, and the stated range covers the measured number.
By their numbers in this assay, from the lowest: compounds 2, 4 and 1 (each within the scatter of the next).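

No step can be read between compound 3 and compound 4 in this assay: compound 3 has no number there to compare. Nothing shown offers an explanation for the result of compound 4. The compounds shown leave open whether benzylsulfonyl in place of hydrogen on that nitrogen shifts this reading at all.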